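This account rests on a few compounds, and the source may have more. Where it says the series, first, only, none or still open, it means among the compounds named here.

Of the compounds shown here, three that share one core have been tested in a functional assay on HT-29 cells (Homo sapiens) for antiproliferative activity, read by MTT assay, with a stated time of 72 h; on this read-out lower numbers stand for stronger inhibition and higher numbers for weaker inhibition. Compound 1, `COc1cc2c(Oc3ccc(NC(=O)c4cc(-c5ccc(F)cc5)on4)cc3)ccnc2cc1OCCCN1CCC(C)CC1`, gives 24600 nM. Compound 2, `COc1cc2c(Oc3ccc(NC(=O)c4nc(-c5ccc(F)cc5)no4)cc3)ccnc2cc1OCCCN1CCC(C)CC1`, gives 6380 nM, and compound 3, `COc1cc2c(Oc3ccc(NC(=O)c4ncc(-c5ccc(F)cc5)o4)cc3)ccnc2cc1OCCCN1CCC(C)CC1`, gives 1890 nM. The three differ only in the five-membered ring on the carbonyl carbon, and each swap moved the number: a 3.9-fold lower number from compound 1 to compound 2 (0.59 log units; beyond the scatter), a 13-fold lower number from compound 1 to compound 3 (1.11 log units; beyond the scatter) and a 3.4-fold lower number from compound 2 to compound 3 (0.53 log units; beyond the scatter). Among these three numbers compound 2 stands second highest, closest to compound 3 and furthest from compound 1.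

Compound 4, `COc1cc2nccc(Oc3ccc(NC(=O)c4nc(-c5ccc(F)cc5)no4)cc3)c2cc1OC`, keeps the ring of compound 2 and changes a different part of the molecule: hydrogen in place of 2-(4-methylpiperidin-1-yl)ethyl on a saturated chain carbon bound to an oxygen on an aromatic ring. For the measured compounds named here, none of the three measured steps touches this side chain; they all concern the ring on the carbonyl carbon, so no measured step speaks directly to this change, and any expectation rests on compound 2 alone. With no guidance from the measured steps, a step in either direction is possible, but a somewhat higher number than compound 2 is taken as the more likely outcome, so a 2.4-fold higher number from compound 2 to compound 4 (0.37 log units; beyond the scatter) is expected. For compound 4 the estimate in this assay is 15000 nM, with a range from 4000 nM to 50000 nM.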

Compound 4, half-maximal inhibitory concentration: 39700 nM
For compound 4 the middle estimate is 2.6-fold (0.42 log units) below the measured one; the measured number falls inside the stated range.
By their numbers in this assay, from the lowest: compound 3; then compound 2; then compounds 1 and 4 (each within the scatter of the next).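

In this assay, for the compounds shown here, cutting the 3-(4-methylpiperidin-1-yl)propoxy side chain back to methoxy gives a 6.2-fold higher number from compound 2 to compound 4 (0.79 log units; beyond the scatter) and shows that this end of the molecule also matters, since all the earlier steps concerned only the ring on the carbonyl carbon. The read-out therefore responds to changes in two separate places, and the change here removes both the saturated chain and its six-membered non-aromatic ring with 1 hetero atom in a single step. No measurement offered here explains the rise in the number.

The compounds shown leave open whether the step comes from the ring, its amine nitrogen or the chain itself, a question that a simple dimethylamino group or a hydroxyl group at the end of the same propoxy chain could help to separate. They also leave open whether the order seen among the rings on the carbonyl carbon holds when methoxy replaces the side chain, for example with the 5-(4-fluorophenyl)-1,3-oxazol-2-yl ring of compound 3.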